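Shortening the butyl chain of compound 1

The source may hold more compounds than are shown below. What is called first, only, known or untested is meant among the compounds shown, and "the series" means these compounds.

In a functional assay on ACHN cells (Homo sapiens) for cytotoxicity, read by sulforhodamine B assay, tested at 10 uM (on this read-out higher numbers stand for more inhibition at the one concentration tested (going by the name of the read-out) and lower numbers for less inhibition), compound 1 `CCCCc1ccc(-c2cc(-c3cn([C@H]4C[C@H](OC(C)=O)[C@@H](COC(C)=O)O4)c(=O)[nH]c3=O)on2)cc1` gives 80.5%, the lowest of the three numbers measured. Compound 2 `CCCCCCCCc1cc(-c2cn([C@H]3C[C@H](O)[C@@H](CO)O3)c(=O)[nH]c2=O)on1` gives 95.6% in this assay, and compound 3 `CC(=O)OC[C@H]1O[C@@H](n2cc(-c3cn(Cc4ccc(C(C)(C)C)cc4)nn3)c(=O)[nH]c2=O)C[C@@H]1OC(C)=O` gives 97.2%; both stand beyond the scatter above compound 1, although neither differs from compound 1 in a single place, so no single step can be read from them.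

Compound 4 `CCc1ccc(-c2cc(-c3cn([C@H]4C[C@H](OC(C)=O)[C@@H](COC(C)=O)O4)c(=O)[nH]c3=O)on2)cc1` has not been measured. It differs from compound 1 by a single change: hydrogen in place of ethyl on a saturated chain carbon, two bonds along the chain from an aromatic carbon. Among the compounds with values here, with no measured pair that isolates this kind of change, the expectation rests only on compound 1 itself and on the observation that the three measured compounds all lie in the upper part of the range.

Compound 4 is expected to land close to compound 1, with a small step down of a number 6.5 percentage points lower from compound 1 to compound 4 (within the scatter) that may well stay within the usual scatter. The estimate for compound 4 in this assay is 74%, with a range from 55% to 90%.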

Compound 4, a percentage reported as inhibition, at one concentration (the size of the read-out at that concentration, not a potency): 92%
For compound 4 the middle estimate is 18 percentage points below the measured one; measured number above the stated range.
By their numbers in this assay, from the lowest: compound 1; then compounds 4, 2 and 3 (each within the scatter of the next).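

In this assay, within the data shown here, trimming butyl to ethyl gives the first step that can be read at this place on the core of compound 1: a number 11.5 percentage points higher from compound 1 to compound 4 (beyond the scatter). On this core, then, the butyl group is not required for a high reading, and the shorter chain gives more inhibition at the one concentration tested. Nothing available here explains why the number rises with this change.

On these data alone, this is a single pair, so it remains open whether a methyl group or a longer chain such as hexyl in place of the butyl group would raise the number further or lower it, and what an amine there would do. Among these compounds, compounds 2 and 3 differ from these two in more than one place, so no steps to them can be read.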